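A few compounds are considered here, and "the series" means these few. Any claim that something is new, unique, unknown or untested is made for them only; others in the source may bear on it.

The measured compounds:

Compound 1, `CCCCOc1ccc2[nH]c(-c3ccccc3)c(C3=C(Br)C(=O)NC3=O)c2c1`: in a physicochemical assay for lipophilicity (a higher number here means a more lipophilic compound, a lower number a more polar compound), compound 1 gives 3.42.
Compound 2, `CCCCCOc1ccc2[nH]c(-c3ccccc3)c(C3=C(Br)C(=O)NC3=O)c2c1`: in this assay compound 2 gives 3.75.
Compound 3, `CCCCc1ccc2[nH]c(-c3ccccc3)c(C3=C(Br)C(=O)NC3=O)c2c1`: in this assay compound 3 gives 3.74.

Compound 4, `CCCCCc1ccc2[nH]c(-c3ccccc3)c(C3=C(Br)C(=O)NC3=O)c2c1`, has not yet been measured. It differs from compound 3 by a single small change, (methyl in place of hydrogen on a saturated chain carbon, four bonds along the chain from an aromatic carbon). The same kind of change has been made once among the measured compounds, going from compound 1 to compound 2, (methyl in place of hydrogen on a saturated chain carbon, four bonds along the chain from an oxygen on an aromatic ring), and there it produced a step of a number 0.33 log units higher from compound 1 to compound 2 (beyond the scatter). The two changes are of the same kind but not the same: in the first pair the added methyl sits four bonds along the chain from an oxygen on an aromatic ring, in the second pair four bonds along the chain from an aromatic carbon. The cores of the two pairs differ by butyl in place of butoxy on an aromatic carbon, which in this assay gave a step of a number 0.32 log units higher from compound 1 to compound 3 (beyond the scatter). Compound 2 and compound 3 end up close together, a number 0.01 log units lower from compound 2 to compound 3 (within the scatter).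

For compound 4 the expected step is a number 0.33 log units higher from compound 3 to compound 4 (beyond the scatter). Among the measured compounds shown here, this rests on the single measured example of this kind of change, a number 0.33 log units higher from compound 1 to compound 2 (beyond the scatter), and on the near coincidence of compound 2 and compound 3, which suggests the two cores respond alike. For the measured compounds named here, with only one example, the expectation is tentative. Compound 4 is estimated at 4.07, with a likely range from 3.85 to 4.3.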

Compound 4, partition coefficient: 4.07
Beside the measured number, compound 4's estimate shows no gap at the digits printed, within the range that was stated.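

In this assay, methyl in place of hydrogen on a saturated chain carbon, four bonds along the chain from an aromatic carbon, gave a number 0.33 log units higher from compound 3 to compound 4 (beyond the scatter) and so matched the same kind of change on the butoxy chain, a number 0.33 log units higher from compound 1 to compound 2 (beyond the scatter), which means the step carried over from one core to the other with no difference in size at the digits printed. The other steps fit the same picture: pentyl in place of pentyloxy gave a number 0.32 log units higher from compound 2 to compound 4 (beyond the scatter), about the size of a number 0.32 log units higher from compound 1 to compound 3 (beyond the scatter) for butyl in place of butoxy, and pentyl in place of butoxy, which combines the two changes, gave a number 0.65 log units higher from compound 1 to compound 4 (beyond the scatter), so the two changes simply add up across these four compounds. This is one pair set against one other pair, so it shows agreement between these two cores for this single chain extension, not a rule for other chains or other cores, and nothing available here explains why the steps agree.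

Going by these compounds, whether the step stays the same for a longer chain such as hexyl or hexyloxy remains open, as does what happens when the chain ends in an amine or a carboxylic acid. These compounds also leave open whether the same additivity would appear in any read-out other than this one.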